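Dihydrofuran carboxamide series: hydrogen for fluoro on the benzyl

This account rests on a few compounds, and the source may have more. Where it says the series, first, only, none or still open, it means among the compounds named here.

Measured so far in a functional assay on QGY7701 cells (Homo sapiens) for cytotoxicity, read by MTT assay, with a stated time of 24 h; on this read-out lower numbers stand for stronger inhibition and higher numbers for weaker inhibition:
Compound 1, `C=CC1=C(C(=O)NCc2ccccc2)C(c2ccc(OC)c(OC)c2)OC1`, reaches only the assay limit of > 100000 nM.
Compound 2, `C=CC1=C(C(=O)NCc2ccccc2F)C(c2ccc(F)cc2)OC1`, gives 51400 nM.
Compound 3, `C=CC1=C(C(=O)Nc2ccccc2)C(c2ccc(Cl)c(Cl)c2)OC1`, likewise reaches only the assay limit of > 100000 nM.

For the measured compounds named here, compound 2 thus stands as the only compound with a numeric value; the other two rest at a limit, as summarised in the limit of > 100000 nM in this assay, at which 2 of the 3 values shown sit. Going by the values given here, no pair of measured compounds differs in a single place, so no measured step is available and the weight that any one change carries remains open.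

Compound 4, `C=CC1=C(C(=O)NCc2ccccc2)C(c2ccc(F)cc2)OC1`, differs from compound 2 by hydrogen in place of fluoro on an aromatic carbon, 2-fluorobenzyl to benzyl. With compound 1 and compound 3 giving only limits, nothing in the shown numbers ties the fluoro on the benzyl to a change in the read-out. The expectation is therefore a step of no more than the usual scatter, if anything toward weaker inhibition, given that two of three compounds sit at the limit.

Compound 4 is estimated at 65000 nM, with a range from 25000 nM to 150000 nM, which corresponds to an expected step of a 1.3-fold higher number from compound 2 to compound 4 (0.10 log units; within the scatter).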

Compound 4, half-maximal inhibitory concentration: 67600 nM
Estimate against measurement, compound 4: 1.0-fold (0.02 log units) below; the measured number falls inside the stated range.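

In this assay the series now has its first comparison at a single place, and hydrogen in place of fluoro on an aromatic carbon, 2-fluorobenzyl to benzyl, reads as a 1.3-fold higher number from compound 2 to compound 4 (0.12 log units; within the scatter), so at this position the change cannot be told apart from repeat measurement. Compound 4, which has no fluoro on the benzyl, still gives a number, 67600 nM, so within this pair a numeric read-out does not depend on that fluoro. Even so, both numbers lie in a weak range of the read-out, and the series as shown still rests largely on limits: the limit of > 100000 nM in this assay, at which 2 of the 4 values shown sit.

The compounds shown do not tell whether this aromatic carbon tolerates anything other than hydrogen and fluoro, such as a methoxy group, an amine or a carboxylic acid, or whether a group of that kind would move the number beyond the scatter. For the compounds shown here, also open is what the other places on the shared core contribute, since the 4-fluorophenyl group is common to this pair and no single-place step yet tests it.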